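From 3-chlorophenyl to 4-methylphenyl at the assay limit

The compounds below may be only part of what the source reports. "The series", "measured", "known", "first", "only" and "open" are said of these compounds alone.

In a functional assay on A549 cells (Homo sapiens) for cytotoxicity, read by MTT assay, with a stated time of 72 h (on this read-out lower numbers stand for stronger inhibition and higher numbers for weaker inhibition), compound 1 `CNC(=O)c1cc(Oc2ccc(NC(=O)c3cc(-c4ccc(C(F)(F)F)cc4)ncn3)cc2F)ccn1` gives > 100000 nM, which is a limit and not a number. Compound 2 `CNC(=O)c1cc(Oc2ccc(NC(=O)c3nccc(-c4ccc([N+](=O)[O-])cc4)n3)cc2)ccn1` gives > 100000 nM, which is also a limit. Compound 3 `CNC(=O)c1cc(Oc2ccc(NC(=O)c3nccc(-c4cccc(Cl)c4)n3)cc2)ccn1` gives > 100000 nM, again a limit. Compound 3 therefore stands with the other two at the limit of > 100000 nM in this assay, at which 3 of the 3 values shown sit, and no true value is known for any of them.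

Compound 4 `CNC(=O)c1cc(Oc2ccc(NC(=O)c3nccc(-c4ccc(C)cc4)n3)cc2)ccn1` differs from compound 3 by one change: 4-methylphenyl in place of 3-chlorophenyl on an aromatic carbon.

Among the compounds with values here, the only measured step of this kind, a step that the two limits leave unreadable from compound 2 to compound 3, offers no size to carry over. No step beyond the scatter is therefore expected in this assay, and compound 4 is expected to remain at or close to the limit. The expected change is an at least 1.2-fold lower number from compound 3 to compound 4 (0.09 log units; that floor lies within the scatter). For compound 4 the estimate is 80000 nM, with an expected range from 20000 nM to 100000 nM.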

Compound 4, half-maximal inhibitory concentration: 28400 nM
For compound 4 the middle estimate is 2.8-fold (0.45 log units) above the measured one; the measured number falls inside the stated range.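

Groups on this aromatic carbon, next to the ring nitrogen, can bring the read-out off the assay limit: in this assay, 4-methylphenyl in place of 3-chlorophenyl gives an at least 3.5-fold lower number from compound 3 to compound 4 (0.54 log units; beyond the scatter). Methyl in place of nitro gives an at least 3.5-fold lower number from compound 2 to compound 4 (0.54 log units; beyond the scatter), so two different starting groups lead to the same measurable result. Both steps are only floors, and the step between the two starting compounds cannot be read, because compound 2 and compound 3 each sit at a limit and not at a number: the limit of > 100000 nM in this assay, at which 3 of the 4 values shown sit.

The change from 3-chlorophenyl to 4-methylphenyl alters both the group on the phenyl ring and where it sits, and 4-chlorophenyl or 3-methylphenyl would be needed to separate these two changes. Going by these compounds, whether an amine or a methoxy group in place of the methyl would lower the number further also remains open.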